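Changing the Anilino Aryl Group on a Shared Core

The compounds below may be only part of what the source reports. "The series", "measured", "known", "first", "only" and "open" are said of these compounds alone.

Measured in a functional assay on HT-29 cells (Homo sapiens) for cytotoxicity, read by MTT assay, with a stated time of 72 h; on this read-out higher numbers stand for weaker inhibition and lower numbers for stronger inhibition:
Compound 1, `COc1ccc(Nc2cc(Nc3ccc(Oc4ccncc4-c4cccnc4)c(F)c3)ncn2)cc1`, gives 4110 nM.
Compound 2, `Fc1ccc(Nc2cc(Nc3ccc(Oc4ccncc4-c4cccnc4)c(F)c3)ncn2)cc1F`, gives 2320 nM.

For the measured compounds named here, compound 2 holds the lower of the two numbers, but its only neighbour is compound 1 and the step of a 1.8-fold lower number from compound 1 to compound 2 (0.25 log units; within the scatter) stays within the scatter, so the two compounds cannot be told apart on these data. Compound 3, `Fc1cc(Nc2cc(Nc3ccc(Cl)cc3)ncn2)ccc1Oc1ccncc1-c1cccnc1`, is the next variation at the same place: 4-chlorophenyl in place of 3,4-difluorophenyl on a nitrogen on an aromatic ring. Going by the values given here, only one measured step bears on this position, the one from compound 1 to compound 2, and it did not rise above the scatter. Nothing here therefore suggests that replacing one halogenated phenyl with another at this nitrogen will move the number beyond the scatter, and compound 3 is expected to show a 1.1-fold higher number from compound 2 to compound 3 (0.03 log units; within the scatter). On that basis compound 3 is estimated at 2500 nM, with a range from 1000 nM to 6500 nM.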

Compound 3, half-maximal inhibitory concentration: 980 nM
For compound 3 the middle estimate is 2.6-fold (0.41 log units) above the measured one, and the stated range ends above it.
By their numbers in this assay, from the lowest: compound 3; then compounds 2 and 1 (each within the scatter of the next).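

In this assay the aryl group on this nitrogen now shows an effect beyond the scatter: 4-chlorophenyl in place of 3,4-difluorophenyl gives a 2.4-fold lower number from compound 2 to compound 3 (0.37 log units; beyond the scatter) on the shared core, something the step between compound 1 and compound 2 could not show. Chloro in place of methoxy on an aromatic carbon gives a 4.2-fold lower number from compound 1 to compound 3 (0.62 log units; beyond the scatter) and so separates compound 3 from both other compounds, although both steps are modest. Nothing measured here accounts for the difference between these aryl groups.

The compounds shown leave open how a 4-bromophenyl or 4-methylphenyl group would read at this nitrogen, and whether an amine or a carboxylic acid on the phenyl ring would be tolerated. They also leave open whether the 4-chlorophenyl step would carry over to a different core.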